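Aryl swap on a cyclopropanecarboxamide series, compound 2 to 3

The source may hold more compounds than are shown below. What is called first, only, known or untested is meant among the compounds shown, and "the series" means these compounds.

Measured so far:
compound 1 `CC[C@H](C)[C@H](N)CN(C(=O)[C@@H]1C[C@H]1c1ccc(C#N)cc1)c1ccc(-c2ccccc2)cc1` gives > 25000 nM in a functional assay for agonist activity at G protein-coupled receptor 88 (Homo sapiens), read by HTRF and cAMP accumulation; on this read-out lower numbers stand for an effect already at smaller amounts and higher numbers for an effect only at larger amounts of compound
compound 2 `CC(C)C[C@H](N)CN(C(=O)[C@@H]1C[C@H]1c1ccccc1)c1ccc(-c2ccncc2)cc1` gives 13000 nM in this assay

For compound 1 the value in this assay is a limit of the assay, not a number; (the limit of > 25000 nM in this assay, at which 1 of the 2 values shown sits). Among the compounds with values here, compound 2 thus holds the only number, and its place cannot be ranked against anything.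

Compound 3 `CC(C)C[C@H](N)CN(C(=O)[C@@H]1C[C@H]1c1ccccc1)c1ccc(-c2ccccc2Cl)cc1` is not yet measured. It differs from compound 2 as follows: 2-chlorophenyl in place of pyridin-4-yl on an aromatic carbon. Without any measured pair of this kind, the step of a 2.2-fold lower number from compound 2 to compound 3 (0.34 log units; beyond the scatter) is expected to be modest and toward smaller amounts, but it may well sit within the scatter. Compound 3 is estimated at 6000 nM, within 2000 nM to 20000 nM.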

Compound 3, half-maximal effective concentration: 3800 nM
Beside the measured number, compound 3's estimate is 1.6-fold (0.20 log units) above it, and the stated range covers the measured number.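

In this assay, within the data shown here, the aromatic carbon para to a large group responds to the choice of aryl group: 2-chlorophenyl in place of pyridin-4-yl gives a 3.4-fold lower number from compound 2 to compound 3 (0.53 log units; beyond the scatter), the first readable step. The change removes the ring nitrogen and adds a chlorine at once, and this single pair cannot separate the two. Nothing measured here accounts for the step.

Which of the two changes carries the step remains open. Plain phenyl at this place, or a methoxy or nitrile group on that ring, could help to separate them.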